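Amide to Urea Swap on a Shared Pyrazole Scaffold

A few compounds are considered here, and "the series" means these few. Any claim that something is new, unique, unknown or untested is made for them only; others in the source may bear on it.

Measured so far:
compound 1 `COc1cc(-c2nn(-c3cccc(NC(=O)c4ccc(Cl)c(C(F)(F)F)c4)c3)cc2-c2ccncc2)ccc1Cl` gives 848 nM
compound 2 `O=C(Nc1cccc(-n2cc(-c3ccncc3)c(-c3ccc(Cl)c(O)c3)n2)c1)Nc1cc(C(F)(F)F)cc(C(F)(F)F)c1` gives 922 nM

Both values come from a functional assay on SR cells (Homo sapiens) for inhibition, read by sulforhodamine B assay, with a stated time of 48 h; a higher number here means a weaker inhibitor of growth, a lower number a stronger inhibitor of growth. Compound 1 gives the lowest of the two numbers, but compound 2 sits within the scatter of it, so the two cannot be told apart. Compound 2 already carries a urea linker, while compound 1 carries an amide, and the two end up in the same range.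

Compound 3 `COc1cc(-c2nn(-c3cccc(NC(=O)Nc4cccc(C(F)(F)F)c4)c3)cc2-c2ccncc2)ccc1Cl` is not yet measured. It differs from compound 1 in one place: (3-(trifluoromethyl)phenyl)amino in place of 4-chloro-3-(trifluoromethyl)phenyl on a carbonyl carbon. This turns the amide of compound 1 into a urea, as in compound 2, and trades one halogen for a hydrogen-bond donor. Since compound 2, which holds a urea, gives 922 nM, no change beyond the scatter is expected. The step of a 1.1-fold higher number from compound 1 to compound 3 (0.03 log units; within the scatter) is expected to be small, in either direction. Compound 3 is estimated at 900 nM, in the range 350 nM to 2500 nM.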

Compound 3, concentration for 50% growth inhibition: 886 nM
Estimate against measurement, compound 3: 1.0-fold (0.01 log units) above; the measured number falls inside the stated range.
By their numbers in this assay, from the lowest: compounds 1, 3 and 2 (each within the scatter of the next).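

In this assay the exchange of 4-chloro-3-(trifluoromethyl)phenyl for (3-(trifluoromethyl)phenyl)amino on a carbonyl carbon gives a 1.0-fold higher number from compound 1 to compound 3 (0.02 log units; within the scatter) and so leaves the number unchanged within the scatter. Among these compounds, compound 2 differs from compound 1 in more than one place, so this pair is the first to show, in a single step, that this position accepts a urea in place of an amide, with the chlorine gone as well. No measurement at hand explains this outcome.

The step makes two changes at once, so the compounds shown leave open what the added amino nitrogen and the lost chlorine each contribute. They also leave open how a very different group on the same carbonyl carbon, such as a morpholine or a simple ethyl chain, would read.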